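Methyl on the side-chain oxygen across two amide cores

This account rests on a few compounds, and the source may have more. Where it says the series, first, only, none or still open, it means among the compounds named here.

Compound 1 `CCCCC(O)c1cccc(NC(=O)NC(=O)CCl)c1` carries a hydroxy group on its side chain. In a functional assay on MCF7 cells (Homo sapiens) for antiproliferative activity, with a stated time of 48 h (a higher number here means a weaker inhibitor, a lower number a stronger inhibitor), compound 1 gives 5700 nM. Compound 2 `CCCCC(OC)c1cccc(NC(=O)NC(=O)CCl)c1` differs from it by methyl in place of hydrogen on an oxygen on a saturated carbon, and in this assay compound 2 gives 6100 nM; the step of a 1.1-fold higher number from compound 1 to compound 2 (0.03 log units; within the scatter) is within the scatter. Compound 3 `CCCCC(O)c1cccc(NC(=O)CCCCl)c1` has a different core, the difference being (3-chloropropyl in place of ((chloromethyl)carbonyl)amino on a carbonyl carbon). In this assay compound 3 gives only a limit, > 100000 nM, as noted in the limit of > 100000 nM in this assay, at which 1 of the 3 values shown sits. The step of an at least 17-fold higher number from compound 1 to compound 3 (1.24 log units; beyond the scatter) is large. Compound 4 `CCCCC(OC)c1cccc(NC(=O)CCCCl)c1` differs from compound 3 by methyl in place of hydrogen on an oxygen on a saturated carbon, the same change as from compound 1 to compound 2. Compound 4 is expected to show a step that the limit leaves unreadable from compound 3 to compound 4, because the corresponding step of a 1.1-fold higher number from compound 1 to compound 2 (0.03 log units; within the scatter) was within the scatter. Compound 4 is therefore estimated to give 150000 nM in this assay, most likely again as a limit, ranging from 80000 nM to 400000 nM.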

Compound 4, half-maximal inhibitory concentration: > 100000 nM
Compound 4 was reported as a limit (the forecaster's own chance of this, stated with the estimate: 85%); the middle value does not contradict the limit.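

In this assay compound 4 gives > 100000 nM, a limit of the assay and not a number, so the step from hydroxy to methoxy cannot be read on the core of compound 3: the limit of > 100000 nM in this assay, at which 2 of the 4 values shown sit.

The core change itself gives an at least 16-fold higher number from compound 2 to compound 4 (1.21 log units; beyond the scatter), which makes it large with either side chain: the same change on two cores in this assay, an at least 17-fold higher number (1.24 log units; beyond the scatter) from compound 1 to compound 3 and an at least 16-fold higher number (1.21 log units; beyond the scatter) from compound 2 to compound 4; the limit leaves it open whether they differ

This shows that the loss from the core change persists with methoxy in place of hydroxy, but it neither confirms nor refutes that the methyl change carries over from the core of compound 1 to the core of compound 3.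

The compounds shown leave open what an ethoxy group or an amine in place of the hydroxy would do on the core of compound 1. They also leave open whether a longer chain on that core would change the value.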